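This account rests on a few compounds, and the source may have more. Where it says the series, first, only, none or still open, it means among the compounds named here.

Measured so far:
compound 1 `O=C(CCCCC1CCSS1)NCc1cn(CCCOc2ccc3cc(-c4ccc(Cl)c(Cl)c4)c(=O)oc3c2)nn1` — 49.6% in a functional assay on PC-12 cells (Rattus norvegicus) for cytotoxicity, read by MTT assay, with stated times of 3 h and 2 h, tested at 10 uM; a higher number here means a stronger effect of the compound at the concentration tested, a lower number a weaker effect
compound 2 `O=C(CCCCC1CCSS1)NCc1cn(CCCCOc2ccc3ccc(=O)oc3c2)nn1` — 65.1% in this assay

In this assay compound 2 stands highest of the two numbers; the nearest, compound 1, lies a gap lower that is beyond the scatter. Among the compounds with values here, the two compounds differ in more than one place, so no single step is read from them.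

Compound 3 `O=C(CCCCC1CCSS1)NCc1cn(CCCCOc2ccc3cc(-c4ccc(Cl)cc4)c(=O)oc3c2)nn1` is not yet measured. It differs from compound 2 by 4-chlorophenyl in place of hydrogen on an aromatic carbon. Within the data shown here, no measured pair shows this change alone. Compound 1, which also carries an aryl substituent on the shared core, gives a lower number than compound 2, which points to a downward step of moderate size, though the comparison is confounded and the range must stay wide.

The step from compound 2 to compound 3 is expected to be a number 10.1 percentage points lower from compound 2 to compound 3 (beyond the scatter). For compound 3 in this assay the expected value is 55%, with a range from 40% to 70%.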

Compound 3, a percentage reported as activity, at one concentration (the size of the read-out at that concentration, not a potency): 61.8%
Estimate against measurement, compound 3: 6.8 percentage points below; low and high end bracket the measured number.
By their numbers in this assay, from the lowest: compound 1; then compounds 3 and 2 (each within the scatter of the next).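

In this assay a reading of a number 3.3 percentage points lower from compound 2 to compound 3 (within the scatter) comes with 4-chlorophenyl in place of hydrogen on the aromatic carbon two atoms from the ring oxygen, so this carbon carries that aryl group with no shift beyond the scatter. Within the data shown here, this is the first reading of this position from a change in one place only, and it does not support the downward step suggested by compound 1, whose steps to the other compounds cannot be read because it differs from each in more than one place. No measurement available bears on why the number stays within the scatter.

As far as these compounds go, whether this holds for an unsubstituted phenyl, a carboxylic acid or an amine on the same carbon remains open. Also open, from the compounds shown here alone, is how a longer chain between the triazole and the shared core would read with the 4-chlorophenyl group in place.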